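Cytotoxicity notes on the bromonaphthyl ether series

A few compounds are considered here, and "the series" means these few. Any claim that something is new, unique, unknown or untested is made for them only; others in the source may bear on it.

Compound 3 `CCN(CC)C(=O)Nc1ncc(C(Oc2ccc3cc(Br)ccc3c2)c2ccc(Cl)cc2)s1` is recorded in an ADME assay on HepG2 2.2.15 cells (Homo sapiens) for cytotoxicity (on this read-out higher numbers stand for lower toxicity in this test and lower numbers for higher toxicity in this test), as "not toxic" (no number reported), so no single number places it. Compound 1 `COCCCNc1ncc(C(Oc2ccc3cc(Br)ccc3c2)c2ccc(Cl)cc2)s1` is recorded in this assay as "not toxic" (no number reported). Compound 2 `CCCCCC(=O)Nc1ncc(C(Oc2ccc3cc(Br)ccc3c2)c2ccc(Cl)cc2)s1` reaches in this assay only a limit, > 50000 nM. Of the three entries shown, one is a limit and two carry no number, and the limit of > 50000 nM in this assay, at which 1 of the 3 values shown sits, marks that one limit. Compound 4 `O=C(Nc1ncc(C(Oc2ccc3cc(Br)ccc3c2)c2ccc(Cl)cc2)s1)c1ccc(F)cc1` carries the change (4-fluorophenyl in place of diethylamino on a carbonyl carbon), in words 4-fluorophenyl in place of diethylamino on a carbonyl carbon. Going by the values given here, no step between measured compounds is given, so nothing here sizes a change of this kind. Compound 2 also carries a carbonyl on the amide-type nitrogen and gives in this assay a limit, > 50000 nM. The step from compound 3 to compound 4 in this assay is therefore expected to be none beyond the scatter, with the result most likely again reported as a limit. Compound 4 is expected at 50000 nM, between 15000 nM and 200000 nM.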

Compound 4, half-maximal cytotoxic concentration: "not toxic" (no number reported)
No number was reported for compound 4, and the estimate cannot be compared.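

In this assay, going by these compounds alone, compound 3 and compound 4 both stand without a number, so no step between them can be read. The compounds shown leave open whether any group on the shared core gives a measurable half-maximal cytotoxic concentration, as none carries a single number.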